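This account rests on a few compounds, and the source may have more. Where it says the series, first, only, none or still open, it means among the compounds named here.

Compound 1 `CCN(CC)CCNC(=O)c1ccc(C(CC)(CC)c2ccc(OCC(=O)C(C)(C)C)c(C)c2)n1CC` carries a (2-(diethylamino)ethyl)amino group on a carbonyl carbon of the shared core. In an assay on HL-60 cells for agonist activity at vitamin D3 receptor (Homo sapiens), read by microscopy, with a stated time of 96 h (on this read-out higher numbers stand for an effect only at larger amounts of compound and lower numbers for an effect already at smaller amounts), compound 1 gives 91 nM, the second highest of the three measured numbers. Compound 2 `CCN(CC)CCCNC(=O)c1ccc(C(CC)(CC)c2ccc(OCC(=O)C(C)(C)C)c(C)c2)n1CC` gives 22 nM, a change of a 4.1-fold lower number from compound 1 to compound 2 (0.62 log units; beyond the scatter), whereas compound 3 `CCn1c(C(=O)N(C)CCC#N)ccc1C(CC)(CC)c1ccc(OCC(=O)C(C)(C)C)c(C)c1` gives 9800 nM, a change of a 110-fold higher number from compound 1 to compound 3 (2.03 log units; beyond the scatter). Compound 4 `CCn1c(C(=O)N(C)c2ccccc2)ccc1C(CC)(CC)c1ccc(OCC(=O)C(C)(C)C)c(C)c1` differs from compound 1 by methyl(phenyl)amino in place of (2-(diethylamino)ethyl)amino on a carbonyl carbon. Among the compounds with values here, the step that bears on this is the one to compound 3, where the same group was exchanged for (2-cyanoethyl)(methyl)amino and gave a 110-fold higher number from compound 1 to compound 3 (2.03 log units; beyond the scatter); the step of a 450-fold higher number from compound 2 to compound 3 (2.65 log units; beyond the scatter) points the same way. A large rise is therefore expected, and compound 4 is estimated to show a 66-fold higher number from compound 1 to compound 4 (1.82 log units; beyond the scatter), giving 6000 nM with a range from 1200 nM to 30000 nM.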

Compound 4, half-maximal effective concentration: 18500 nM
Beside the measured number, compound 4's estimate is 3.1-fold (0.49 log units) below it, and the stated range covers the measured number.
By their numbers in this assay, from the lowest: compound 2; then compound 1; then compounds 3 and 4 (each within the scatter of the next).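

In this assay, phenyl in place of 2-cyanoethyl on the amide-type nitrogen gives a 1.9-fold higher number from compound 3 to compound 4 (0.28 log units; within the scatter), so the two groups are not told apart here. A second, quite different group on the carbonyl carbon thus also departs far from the diethylamino chains, with a 200-fold higher number from compound 1 to compound 4 (2.31 log units; beyond the scatter) and an 840-fold higher number from compound 2 to compound 4 (2.92 log units; beyond the scatter). Nothing available explains this shift. The compounds shown leave open whether the lower numbers go with the amide hydrogen or with the diethylamino group. A (2-cyanoethyl)amino or methyl(2-(diethylamino)ethyl)amino group on the carbonyl carbon would bear on that.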